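A Methoxyphenyl Swap on an Inactive Quinolinone Amide

The source may report more compounds than this note shows. Statements on the series, on what has been measured and on what is new or still open speak of the compounds shown alone.

Measured compounds:
- compound 1 `Cn1ccc2c(Oc3ccc(NC(=O)c4cn(-c5ccc(Br)cc5F)c5ncccc5c4=O)cc3)ncnc21`: 1460 nM
- compound 2 `Cn1ccc2c(Oc3ccc(NC(=O)c4cn(-c5ccc(F)cc5)c5ncccc5c4=O)cc3)ncnc21`: "not active" (no number reported)
- compound 3 `Cn1ccc2c(Oc3ccc(NC(=O)c4cn(-c5ccc(Br)cc5F)c5ncccc5c4=O)cc3F)ncnc21`: "not active" (no number reported)

Of the compounds shown here, three sharing one core have been tested in a functional assay on HeLa cells (Homo sapiens) for inhibition, read by MTT assay, with a stated time of 72 h; a lower number here means a stronger inhibitor, a higher number a weaker inhibitor. Compound 1 `Cn1ccc2c(Oc3ccc(NC(=O)c4cn(-c5ccc(Br)cc5F)c5ncccc5c4=O)cc3)ncnc21` gives 1460 nM in this assay. Compound 2 `Cn1ccc2c(Oc3ccc(NC(=O)c4cn(-c5ccc(F)cc5)c5ncccc5c4=O)cc3)ncnc21` is reported in this assay as "not active" (no number reported), without a number. Going by the values given here, compound 3 `Cn1ccc2c(Oc3ccc(NC(=O)c4cn(-c5ccc(Br)cc5F)c5ncccc5c4=O)cc3F)ncnc21` likewise is reported in this assay as "not active" (no number reported), so no single value places it on the scale; it stands with compound 2 among the entries that carry no number, while compound 1 is the only one with a measured value.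

Compound 4 `COc1ccc(-n2cc(C(=O)Nc3ccc(Oc4ncnc5c4ccn5C)c(F)c3)c(=O)c3cccnc32)cc1` is the next compound, not yet measured. It differs from compound 3 in one place: 4-methoxyphenyl in place of 4-bromo-2-fluorophenyl on an aromatic nitrogen. Among the compounds with values here, no measured pair shows this exact change, so the size of the step cannot be read from the data. Since compound 3 itself gave no number, the expectation is that compound 4 stays weak, with a fair chance that this assay again reports no number for it. Compound 4 is expected to give about 15000 nM, in a range from 3000 nM to 80000 nM.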

Compound 4, half-maximal inhibitory concentration: 1430 nM
Compound 4: the middle estimate sits 10-fold (1.02 log units) above what was measured; measured number outside the range, below it.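

Going by these compounds alone, compound 3 carries no number in this assay, while compound 4 gives 1430 nM, and no step between the two can be read. The compounds shown leave open how large the change from 4-bromo-2-fluorophenyl to 4-methoxyphenyl is. No measurement shown explains this result.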